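Demethylation on the Shared Core: Compound 2 to Compound 3

A few compounds are considered here, and "the series" means these few. Any claim that something is new, unique, unknown or untested is made for them only; others in the source may bear on it.

Compound 2 `COc1cc(-c2nn(-c3cccc(NC(=O)Nc4ccc(Cl)c(Cl)c4)c3)cc2-c2ccncc2)ccc1Cl` was examined in a functional assay on SK-MEL-2 cells (Homo sapiens) for inhibition, read by sulforhodamine B assay, with a stated time of 48 h (on this read-out higher numbers stand for weaker inhibition of growth and lower numbers for stronger inhibition of growth), where compound 2 gives 1140 nM. Among the compounds with values here, on the numbers so far, compound 2 carries the lower of the two values, but its only companion, compound 1 `O=C(Nc1cccc(-n2cc(-c3ccncc3)c(-c3ccc(Cl)c(O)c3)n2)c1)Nc1cccc(C(F)(F)F)c1`, with 2020 nM in this assay, lies within the scatter of it, so nothing separates the two beyond what repeated measurements would show. Compound 1 differs from compound 2 in two places at once, so its value says little about either change on its own.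

Compound 3 `O=C(Nc1cccc(-n2cc(-c3ccncc3)c(-c3ccc(Cl)c(O)c3)n2)c1)Nc1ccc(Cl)c(Cl)c1` takes a single step away from compound 2: hydrogen in place of methyl on an oxygen on an aromatic ring. The urea part of compound 2 is kept unchanged.

Within the data shown here, with no step between measured compounds that isolates this change, there is no basis in these data for expecting a shift beyond the scatter in either direction. Compound 3 is therefore expected to land close to compound 2, with an estimated step of a 1.1-fold higher number from compound 2 to compound 3 (0.02 log units; within the scatter) in this assay. The estimate for compound 3 is 1200 nM, with a range from 500 nM to 3000 nM.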

Compound 3, concentration for 50% growth inhibition: 1030 nM
Compound 3: middle estimate off by 1.2-fold (0.07 log units), on the high side; low and high end bracket the measured number.
By their numbers in this assay, from the lowest: compounds 3, 2 and 1 (each within the scatter of the next).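

In this assay, within the data shown here, the change from methoxy to hydroxy on the 4-chloro-3-methoxyphenyl group gives a 1.1-fold lower number from compound 2 to compound 3 (0.04 log units; within the scatter), the first reading of this change on its own, and it shows that removing the methyl from this oxygen does not move the value beyond the scatter. Compound 3 also isolates the second change that was combined in the comparison of compound 1 with compound 2: with the 4-chloro-3-hydroxyphenyl group held constant, 3,4-dichlorophenyl in place of 3-(trifluoromethyl)phenyl on the urea gives a 2.0-fold lower number from compound 1 to compound 3 (0.29 log units; within the scatter), which also stays within the scatter. No independent evidence accompanies these values to account for either result.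

The compounds shown leave open whether a longer chain on the oxygen, such as ethoxy or propoxy, or an amine or a carboxylic acid in place of the hydroxy group would shift the value beyond the scatter. They also leave open how the value would respond if the chlorine of the 4-chloro-3-hydroxyphenyl group gave way to hydrogen or fluorine.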